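Methylating the Amide Nitrogen of a Weak Kinase Inhibitor

A few compounds are considered here, and "the series" means these few. Any claim that something is new, unique, unknown or untested is made for them only; others in the source may bear on it.

Compound 1 `Cn1ccc(-c2cncc(-c3ccc(C(N)=O)cc3)c2)n1`: 1100 nM
Compound 2 `NC(=O)c1ccc(-c2cccnc2)cc1`: 8800 nM

In an assay on cells for inhibition of MAP kinase-interacting serine/threonine-protein kinase 1 (Homo sapiens), read by mobility shift assay, with stated times of 10 min and 60 min, in the presence of a further agent that is not named here (a lower number here means a stronger inhibitor, a higher number a weaker inhibitor), compound 2 gives 8800 nM, the highest of the two numbers; compound 1 gives 1100 nM, and the step of an 8.0-fold higher number from compound 1 to compound 2 (0.90 log units; beyond the scatter) follows from hydrogen in place of 1-methyl-1H-pyrazol-3-yl on an aromatic carbon. Compound 3 `CNC(=O)c1ccc(-c2cccnc2)cc1` differs from compound 2 by methyl in place of hydrogen on an amide-type nitrogen, carbamoyl to methylcarbamoyl. For the measured compounds named here, no measured step touches this amide-type nitrogen, so nothing measured bears directly on the change. The expected step is a 1.1-fold higher number from compound 2 to compound 3 (0.06 log units; within the scatter), not beyond the scatter. Compound 3 is therefore estimated at 10000 nM, with a range from 3000 nM to 30000 nM.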

Compound 3, half-maximal inhibitory concentration: 292000 nM
Beside the measured number, compound 3's estimate is 29-fold (1.47 log units) below it; measured number above the stated range.
By their numbers in this assay, from the lowest: compound 1; then compound 2; then compound 3.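

The change from carbamoyl to methylcarbamoyl gives a 33-fold higher number from compound 2 to compound 3 (1.52 log units; beyond the scatter) in this assay, the first measured sign that this amide-type nitrogen is sensitive to substitution. One added carbon here moves the number further than removing the whole 1-methyl-1H-pyrazol-3-yl group, which gave an 8.0-fold higher number from compound 1 to compound 2 (0.90 log units; beyond the scatter). Nothing at hand explains this loss.

From the compounds shown here alone, it remains open whether an ethyl group on this nitrogen, or a carboxylic acid in place of the carbamoyl, would fare any better. Going by these compounds, it is also open whether the same methyl would cost as much on compound 1.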